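The source may report more compounds than this note shows. Statements on the series, on what has been measured and on what is new or still open speak of the compounds shown alone.

Measured compounds:
compound 1, `CC(C)c1c(C(=O)N(C)Cc2ccccc2)nn(-c2ccc(F)cc2)c1CC[C@@H](O)C[C@@H](O)CC(=O)O`, 2870 nM
compound 2, `CC(C)c1c(C(=O)N2CCC[C@H](c3ccccc3)C2)nn(-c2ccc(F)cc2)c1OC[C@@H](O)C[C@@H](O)CC(=O)O`, 1110 nM

Both compounds were tested in a functional assay on L6 cells (Rattus norvegicus) for inhibition; a lower number here means a stronger inhibitor, a higher number a weaker inhibitor. Of the two, compound 2 gives the lower number, 1110 nM, and compound 1 the higher, 2870 nM; the gap between them lies beyond the scatter, but the two structures differ in more than one place, so no single change can be credited with it.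

Compound 3, `CC(C)c1c(C(=O)N(C)Cc2cccc(F)c2)nn(-c2ccc(F)cc2)c1OC[C@@H](O)C[C@@H](O)CC(=O)O`, has not yet been measured. It differs from compound 2 in one place: (3-fluorobenzyl)(methyl)amino in place of 3-phenylpiperidin-1-yl on a carbonyl carbon. Within the data shown here, the ring amine is replaced by an open benzylamine carrying a fluorine, a grouping close to the one found in compound 1, whose value of 2870 nM is the weaker of the two.

For compound 3 a modest step towards a higher number is expected, a 1.8-fold higher number from compound 2 to compound 3 (0.26 log units; within the scatter), with wide uncertainty. The estimate for compound 3 in this assay is 2000 nM, within 700 nM to 6000 nM.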

Compound 3, half-maximal inhibitory concentration: 2470 nM
The estimate for compound 3 lay 1.2-fold (0.09 log units) below the measured number, within the range that was stated.
By their numbers in this assay, from the lowest: compound 2; then compounds 3 and 1 (each within the scatter of the next).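

At this position on the carbonyl carbon, this assay responds to the amine that is attached: putting (3-fluorobenzyl)(methyl)amino in place of 3-phenylpiperidin-1-yl gives a 2.2-fold higher number from compound 2 to compound 3 (0.35 log units; beyond the scatter). Among these compounds, the earlier pair differed in more than one place, so this is the first gap that can be tied to a single change, and it is a modest weakening rather than a collapse in activity. The swap alters several things at once, removing the non-aromatic ring and its stereocentre while adding a fluorine, and no measurement is available to explain the shift.

Which of these features accounts for the step remains open. A simple piperidin-1-yl or a pyrrolidin-1-yl on the same carbonyl carbon would show how much activity depends on the phenyl group and on the size of the ring.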